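This account rests on a few compounds, and the source may have more. Where it says the series, first, only, none or still open, it means among the compounds named here.

Series notes on the aryl-ether acids. Compound 1 `Cc1oc(CCC(=O)O)cc1COc1ccc(-c2ccccc2)cc1` stands second highest of the three numbers obtained so far in an assay on cells for displacement of a labelled ligand from prostaglandin E2 receptor EP4 subtype (Homo sapiens), read by scintillation counting; on this read-out higher numbers stand for weaker inhibition and lower numbers for stronger inhibition; compound 1 gives 80 nM. Compound 2 `Cc1noc(C)c1S(=O)(=O)NC(=O)c1cc(COc2ccc(-c3ccc(OC(F)F)cc3)cc2)c(C)o1`, which carries an acylsulfonamide in place of the free acid, gives 0.6 nM in this assay, the lowest number of the set. Compound 3 `Cc1oc(C(=O)O)cc1COc1ccc(-c2ccc(C#N)cc2)cc1`, with the acid carried directly on the core and a nitrile on the outer ring, gives 1500 nM in this assay; this number is higher than that of compound 1, beyond the scatter, but since the two structures differ in more than one place the pair shows only its two values.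

Compound 4 `Cc1oc(CC(=O)O)cc1COc1ccc(-c2ccccc2)cc1` differs from compound 1 by carboxy in place of carboxymethyl on a saturated chain carbon bound to an aromatic carbon. Read one bond further out, the acid chain goes from 2-carboxyethyl to carboxymethyl. For the measured compounds named here, no measured pair covers this change alone, so the direction is taken from the acids on hand: compound 3, whose chain is shorter still, gives 1500 nM, a higher number than compound 1. A step toward a higher number, beyond the scatter, is therefore expected, a 3.8-fold higher number from compound 1 to compound 4 (0.57 log units; beyond the scatter). Compound 4 is estimated at 300 nM in this assay, with a range from 100 nM to 1000 nM.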

Compound 4, inhibition constant: 80 nM
The estimate for compound 4 lay 3.8-fold (0.57 log units) above the measured number; measured number outside the range, below it.
By their numbers in this assay, from the lowest: compound 2; then compounds 1 and 4 (each within the scatter of the next); then compound 3.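

In this assay, for the compounds shown here, going from 2-carboxyethyl to carboxymethyl on a saturated chain carbon bound to an aromatic carbon reads as no change at the digits printed from compound 1 to compound 4 (within the scatter), the first step that isolates a single place, so this read-out does not tell these two acid chains apart. Compound 3 differs from compound 1 and from compound 4 in more than one place, so its value cannot be assigned to the chain alone. Nothing on hand gives a reason for this result.

Still open, on these data alone, is how a longer chain, such as 3-carboxypropyl, would read on the core of compound 1, and how a carboxylic acid carried directly on that core would read with the outer ring unsubstituted. Also open, as far as these compounds go, is how an acylsulfonamide would read on the carboxymethyl chain of compound 4.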